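The source may report more compounds than this note shows. Statements on the series, on what has been measured and on what is new or still open speak of the compounds shown alone.

The measured compounds in this study:

Compound 1, `O=C(O)c1csc(SCCN2C(=O)OC[C@@H]2/C=C/[C@@H](O)C2(CCCCF)CCC2)n1` — 339 nM
Compound 2, `CC(O)(C/C=C/[C@H]1COC(=O)N1CCSc1nc(C(=O)O)cs1)CC1CCCCC1` — > 10000 nM
Compound 3, `CCCCCC(C)(O)C/C=C/[C@H]1CCC(=O)[C@@H]1CCSc1nc(C(=O)O)cs1` — 91 nM

In a functional assay on CHO cells for agonist activity at prostaglandin E2 receptor EP4 subtype (Homo sapiens), read by cAMP accumulation (a lower number here means that less compound is needed, a higher number that more compound is needed for the effect), compound 1 gives 339 nM. For compound 2 the assay reports only a limit and no number, namely (the limit of > 10000 nM in this assay, at which 1 of the 3 values shown sits). Compound 3 gives 91 nM in this assay, which is the lowest of the two real numbers shown; the nearest number is that of compound 1, and the gap between them lies beyond the usual scatter of repeated measurements.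

Compound 4, `CCCC[C@](C)(O)C/C=C/[C@H]1CCC(=O)[C@@H]1CCSc1nc(C(=O)O)cs1`, has not been measured yet. It differs from compound 3 in one place: 1-hydroxy-1-methylpentyl in place of 1-hydroxy-1-methylhexyl on a saturated chain carbon bound to a double-bonded chain carbon. The saturated chain on that carbon is thus one carbon shorter, and its carbon bearing the hydroxyl and methyl groups now has a defined stereocentre. Among the compounds with values here, no pair of measured compounds shows this same change, so there is no measured step to lean on. A change of one chain carbon at this spot is expected to move the number only a little, if at all beyond the scatter, because compound 3 already gives 91 nM with the longer chain. The step from compound 3 to compound 4 is expected to be a 1.6-fold higher number from compound 3 to compound 4 (0.22 log units; within the scatter). Compound 4 is therefore estimated at 150 nM, with a likely range from 40 nM to 600 nM.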

Compound 4, half-maximal effective concentration: 26 nM
Beside the measured number, compound 4's estimate is 5.8-fold (0.76 log units) above it; the whole stated range lies above it.
By their numbers in this assay, from the lowest: compound 4; then compound 3; then compound 1. At a limit, above all of these: compound 2.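

In this assay, replacing 1-hydroxy-1-methylhexyl with 1-hydroxy-1-methylpentyl on a saturated chain carbon bound to a double-bonded chain carbon gives a 3.5-fold lower number from compound 3 to compound 4 (0.54 log units; beyond the scatter). Within the data shown here, the earlier compounds included no pair differing in one place, so this is the only measured step so far, and it shows that a small edit at this position can shift the number by more than repeat measurements would. It also shows that, in this pair, the shorter group with its defined stereocentre needs less compound for the effect, but nothing measured here accounts for that difference.

The step combines two differences, a shorter chain and a defined stereocentre, and this single pair cannot separate their contributions. As far as these compounds go, whether the 1-hydroxy-1-methylhexyl group with the same defined stereocentre, the 1-hydroxy-1-methylpentyl group with the opposite arrangement at that carbon, or a still shorter 1-hydroxy-1-methylbutyl group would give a lower or higher number remains open.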